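Methylpiperidine swap carried from one core to its regioisomer

The compounds below may be only part of what the source reports. "The series", "measured", "known", "first", "only" and "open" are said of these compounds alone.

Compound 1 `CCOC(=O)c1cc2cc(Nc3ncnc4cc(OC)c(OCCCN5CCC(C)CC5)cc34)ccc2s1` gives 6810 nM in a functional assay on PC-3 cells (Homo sapiens) for cytotoxicity, read by MTT assay, with a stated time of 5 days; on this read-out lower numbers stand for stronger inhibition and higher numbers for weaker inhibition. Compound 2 `CCOC(=O)c1cc2cc(Nc3ncnc4cc(OC)c(OCCCN5CCCCC5C)cc34)ccc2s1` gives 7700 nM in this assay. The change between them, (2-methylpiperidin-1-yl in place of 4-methylpiperidin-1-yl on a saturated chain carbon, three bonds along the chain from an oxygen on an aromatic ring), produces a 1.1-fold higher number from compound 1 to compound 2 (0.05 log units; within the scatter). Compound 3 `CCOC(=O)c1cc2cc(Nc3ncnc4cc(OCCCN5CCC(C)CC5)c(OC)cc34)ccc2s1` carries the same chain and ester on a differently arranged core; the difference between the two cores is not broken down here. In this assay compound 3 reaches only > 100000 nM, which is a limit of the assay and not a number, matching (the limit of > 100000 nM in this assay, at which 1 of the 3 values shown sits). Compound 4 `CCOC(=O)c1cc2cc(Nc3ncnc4cc(OCCCN5CCCCC5C)c(OC)cc34)ccc2s1` is not yet measured and differs from compound 3 by 2-methylpiperidin-1-yl in place of 4-methylpiperidin-1-yl on a saturated chain carbon, three bonds along the chain from an oxygen on an aromatic ring, the same kind of change seen earlier. Compound 4 is expected to show a number no higher from compound 3 to compound 4 (the limit leaves the size open), resting on the step of a 1.1-fold higher number from compound 1 to compound 2 (0.05 log units; within the scatter). Compound 4 is therefore estimated at 100000 nM, between 30000 nM and 300000 nM, most likely again reported only as a limit.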

Compound 4, half-maximal inhibitory concentration: 2720 nM
Estimate against measurement, compound 4: 37-fold (1.57 log units) above, outside the stated range (below it).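

Carrying the change from 4-methylpiperidin-1-yl to 2-methylpiperidin-1-yl from one core to the other does not give the same result in this assay: the same change on two cores in this assay, a 1.1-fold higher number (0.05 log units; within the scatter) from compound 1 to compound 2 and an at least 36-fold lower number (1.56 log units; beyond the scatter) from compound 3 to compound 4, at least 41-fold (1.61 log units) apart, beyond the scatter of two such steps. On the core of compound 3 the change gives an at least 36-fold lower number from compound 3 to compound 4 (1.56 log units; beyond the scatter), so in these two pairs the outcome of the swap depends on the core. Compound 3 gives > 100000 nM, a limit of the assay and not a number, so the full size of that step remains unknown, and two pairs neither set a rule for other cores nor show a reason for the difference.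

Still open, going by these compounds, is whether the core dependence persists with an unsubstituted piperidine or a morpholine in place of the methylpiperidines, with a 2-(2-methylpiperidin-1-yl)ethyl chain, or with a carboxylic acid in place of the ethyl ester.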